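The source may report more compounds than this note shows. Statements on the series, on what has been measured and on what is new or still open speak of the compounds shown alone.

Among the compounds with values here, in a functional assay on the whole organism with Mus musculus as the target (on this read-out higher numbers stand for an effect only at larger amounts of compound and lower numbers for an effect already at smaller amounts), compound 1 (`CCNC(=O)/C=C/c1cccc(C(F)(F)F)c1`) gives 90 mg/kg, the only true number so far. Compound 2 (`CN(C)C(=O)/C=C/c1cccc(C(F)(F)F)c1`) is recorded at > 75 mg/kg, which is a limit and not a number. Compound 3 (`CN(C)C(=O)CCC(=O)c1cccc(C(F)(F)F)c1`) is recorded at > 50 mg/kg, which is also a limit, so it has no exact place on the scale.

Compound 4 (`CN1CCN(C(=O)CCC(=O)c2cccc(C(F)(F)F)c2)CC1`) keeps the core of compound 3 and changes one group on a carbonyl carbon, where 4-methylpiperazin-1-yl takes the place of dimethylamino: 4-methylpiperazin-1-yl in place of dimethylamino on a carbonyl carbon.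

Within the data shown here, only one measured step involves a change on such a carbonyl carbon: a step that the limit leaves unreadable from compound 1 to compound 2. That step swaps ethylamino for dimethylamino, so it is not the same change, and it has no readable size. Among the measured compounds shown here, no measured step therefore gives either a size or a direction for the new change. The starting point is also only the limit of > 50 mg/kg for compound 3.

With so little to go on, the expectation in this assay is no shift beyond the usual scatter, in either direction. The estimated change is a step that the limit leaves unreadable from compound 3 to compound 4. For compound 4, the estimated value is 70 mg/kg, with an expected range from 30 mg/kg to 160 mg/kg.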

Compound 4, dose for half-maximal effect: > 50 mg/kg
Compound 4 was reported as a limit (the forecaster's own chance of this, stated with the estimate: 50%); the middle value does not contradict the limit.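

In this assay, compound 3 and compound 4 are both recorded only as limits, not as numbers, so the step between them cannot be read: the limit of > 50 mg/kg in this assay, at which 2 of the 4 values shown sit.

The compounds shown leave open whether 4-methylpiperazin-1-yl in place of dimethylamino on a carbonyl carbon shifts the dose for half-maximal effect at all, and in which direction.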